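This account rests on a few compounds, and the source may have more. Where it says the series, first, only, none or still open, it means among the compounds named here.

Measured compounds:
compound 1 `C[C@@H](NC(=O)[C@H](CCCNC(=N)N)NC(=O)c1ccc(CN(Cc2ccncc2)Cc2ccc(F)cc2)cc1)c1cccc2ccccc12` — 12%
compound 2 `C[C@H](NC(=O)[C@H](CCCNC(=N)N)NC(=O)c1ccc(CN(Cc2ccc(F)cc2)Cc2ccccn2)cc1)c1cccc2ccccc12` — 30%
compound 3 `C[C@H](NC(=O)[C@H](CCCNC(=N)N)NC(=O)c1ccc(CN(Cc2ccc(F)cc2)Cc2cccnc2)cc1)c1cccc2ccccc12` — 27%

In an assay on Jurkat cells for displacement of a labelled ligand from C-X-C chemokine receptor type 4 (Homo sapiens), tested at 10 uM (on this read-out higher numbers stand for more inhibition at the one concentration tested (going by the name of the read-out) and lower numbers for less inhibition), compound 3 holds the second highest of the three numbers. Its nearest neighbour is compound 2, which gives 30%, a gap that stays within the scatter; compound 1, which gives 12%, lies well beyond the scatter below it. Compound 4 `C[C@H](NC(=O)[C@H](CCCNC(=N)N)NC(=O)c1ccc(CN(Cc2ccncc2)Cc2ccc(F)cc2)cc1)c1cccc2ccccc12` differs from compound 3 by pyridin-4-yl in place of pyridin-3-yl on a saturated chain carbon bound to an amine nitrogen. Among the measured compounds shown here, the only measured step touching this part of the molecule is a number 3 percentage points lower from compound 2 to compound 3 (within the scatter), which did not leave the scatter. No shown step therefore supports a shift beyond the scatter in this assay for the move to compound 4, and compound 4 is expected to give 25% (range 12% to 38%), an estimated step of a number 2 percentage points lower from compound 3 to compound 4 (within the scatter).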

Compound 4, a percentage reported as inhibition, at one concentration (the size of the read-out at that concentration, not a potency): 16%
The estimate for compound 4 lay 9 percentage points above the measured number, within the range that was stated.
By their numbers in this assay, from the lowest: compounds 1 and 4 (each within the scatter of the next); then compounds 3 and 2 (each within the scatter of the next).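

In this assay, the choice among the pyridine isomers now registers: the move to pyridin-4-yl brings a number 11 percentage points lower from compound 3 to compound 4 (beyond the scatter) and a number 14 percentage points lower from compound 2 to compound 4 (beyond the scatter), whereas the earlier change from pyridin-2-yl to pyridin-3-yl stayed within the scatter. With pyridin-4-yl kept, inverting the stereocentre at the saturated chain carbon leaves a number 4 percentage points higher from compound 1 to compound 4 (within the scatter), and that step rests on one fact: the fact that one of compounds 1 and 4 is drawn with a defined configuration and the other without, at the place where they differ

Still open, from the compounds shown here alone, is whether that stereocentre matters with pyridin-2-yl or pyridin-3-yl in place. Also open, going by these compounds, is how a plain phenyl or a piperidin-4-yl group would read on this saturated chain carbon.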